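Trifluoromethyl to carbamoyl on a pyrazole acid scaffold

The compounds below may be only part of what the source reports. "The series", "measured", "known", "first", "only" and "open" are said of these compounds alone.

Measured compounds:
- compound 1, `Cc1n[nH]c(C(=O)O)c1Cc1cccc(C(F)(F)F)c1`: 5%
- compound 2, `Cc1c(Cc2cccc(-c3ccc(F)cc3)c2)c(C(=O)O)nn1C`: 2%
- compound 3, `Cc1n[nH]c(C(=O)O)c1Cc1ccc(-c2ccc(F)cc2)cc1`: 11%

In an assay on isolated protein for inhibition of 2-Hydroxyacid oxidase 2 (Homo sapiens), tested at 1 uM (a higher number here means a stronger effect of the compound at the concentration tested, a lower number a weaker effect), compound 1 gives 5%. Its number lies within the usual scatter of both compound 2 and compound 3, so these three cannot be placed in any order; all of them show only a small effect at this concentration.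

Compound 4, `Cc1n[nH]c(C(=O)O)c1Cc1cccc(C(N)=O)c1`, has not yet been tested. It differs from compound 1 in one place: carbamoyl in place of trifluoromethyl on an aromatic carbon. For the measured compounds named here, no measured pair shows what this exchange does, so nothing beyond the shared weak signal can be drawn on. The expectation for compound 4 is therefore a step of no change at the digits printed from compound 1 to compound 4 (within the scatter), that is, no change beyond the scatter. Compound 4 is estimated at 5%, with a range from -5% to 15%.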

Compound 4, a percentage reported as inhibition, at one concentration (the size of the read-out at that concentration, not a potency): 8%
The estimate for compound 4 lay 3 percentage points below the measured number; measured number inside the range.
By their numbers in this assay, from the lowest: compounds 2, 1, 4 and 3 (each within the scatter of the next).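

In this assay, carbamoyl in place of trifluoromethyl gives a number 3 percentage points higher from compound 1 to compound 4 (within the scatter). For the compounds shown here, this is the first direct reading at this aromatic carbon: a group with no hydrogen-bond donor or acceptor can give way to one with a donor and an acceptor without a change that can be told from the scatter, and the effect stays small. Nothing available explains this result.

On these data alone, what an amine or a carboxylic acid on this carbon would do remains open. So does whether any exchange here can lift the effect clear of the scatter.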